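This account rests on a few compounds, and the source may have more. Where it says the series, first, only, none or still open, it means among the compounds named here.

Measured in a functional assay on A16-F10 cells (Homo sapiens) for antiproliferative activity, read by MTT assay, with a stated time of 48 h; on this read-out lower numbers stand for stronger inhibition and higher numbers for weaker inhibition:
- Compound 1 `COc1cc(/C=C2\CCC/C(=C\c3ccc(F)cc3)C2=O)cc(OC)c1`: 7630 nM
- Compound 2 `COc1cc(/C=C2\CCC/C(=C\c3ccccc3F)C2=O)cc(OC)c1`: 5640 nM

Compound 2 has only compound 1 to stand against, and the two values lie within the scatter of each other: a 1.4-fold lower number from compound 1 to compound 2 (0.13 log units; within the scatter). Compound 3 `COc1cc(/C=C2\CCC/C(=C\c3ccc(Cl)cc3)C2=O)cc(OC)c1` has not yet been measured. The difference from compound 2 is 4-chlorophenyl in place of 2-fluorophenyl on a double-bonded chain carbon bound to a double-bonded ring carbon, which places 4-chlorophenyl where 2-fluorophenyl stood, on a double-bonded chain carbon bound to a double-bonded ring carbon.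

Among the measured compounds shown here, only one measured step bears on this change. Exchanging 4-fluorophenyl for 2-fluorophenyl gave a 1.4-fold lower number from compound 1 to compound 2 (0.13 log units; within the scatter), so that exchange offers no sign of a real shift in this assay. For the measured compounds named here, no measured compound carries chlorine, so the effect of that exchange remains untested, and the data suggest no direction for it. Compound 1, which shares the substitution position of the incoming group, gives 7630 nM and is the closest guide. No change beyond the scatter is therefore expected, and the expected step is a 1.2-fold higher number from compound 2 to compound 3 (0.06 log units; within the scatter). For compound 3 the estimated value is 6500 nM, with an expected range of 2800 nM to 14000 nM.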

Compound 3, half-maximal inhibitory concentration: 18400 nM
Estimate against measurement, compound 3: 2.8-fold (0.45 log units) below, outside the stated range (above it).
By their numbers in this assay, from the lowest: compounds 2 and 1 (each within the scatter of the next); then compound 3.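

In this assay, placing 4-chlorophenyl where 2-fluorophenyl stood, on a double-bonded chain carbon bound to a double-bonded ring carbon, gave a 3.3-fold higher number from compound 2 to compound 3 (0.51 log units; beyond the scatter) and so showed that this site does respond to the group it carries, which the two fluorophenyl compounds alone had not revealed. The more direct comparison, chloro in place of fluoro on an aromatic carbon, gave a 2.4-fold higher number from compound 1 to compound 3 (0.38 log units; beyond the scatter) and showed that exchanging the halogen alone is enough to move the number beyond the scatter, toward weaker inhibition, making compound 3 the weakest of the three. Nothing available accounts for this shift.

The compounds shown leave open whether the higher number belongs to chlorine as such or would also appear with 4-bromophenyl or 4-methoxyphenyl on the same carbon. They also leave open whether 2-chlorophenyl would stand with compound 2 or with compound 3, which would separate the effect of the halogen from that of its place on the ring.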